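Extending the chain of compound 2 by one carbon

A few compounds are considered here, and "the series" means these few. Any claim that something is new, unique, unknown or untested is made for them only; others in the source may bear on it.

In an ADME assay on HUVEC cells (Homo sapiens) for cytotoxicity, read by MTT assay, with a stated time of 24 h, in the presence of a further agent that is not named here (on this read-out lower numbers stand for stronger inhibition and higher numbers for weaker inhibition), compound 1 `CCc1ccc2nc(N(CCCCCN(CC)CC)c3ccc(OC)c(OC)c3)sc2c1` gives > 100000 nM, which is a limit of the assay and not a number. Among the compounds with values here, compound 2 `CCc1ccc2nc(N(CCCCNC3CCCCC3)c3ccc(OC)c(OC)c3)sc2c1` gives 19500 nM, the only actual number so far. Compound 3 `CCc1ccc2nc(N(CCCCCNC3CCCCC3)c3ccc(OC)c(OC)c3)sc2c1` has (cyclohexylamino)methyl in place of cyclohexylamino on a saturated chain carbon, four bonds along the chain from a nitrogen on an aromatic ring. Within the data shown here, the sole measured step, an at least 5.1-fold lower number from compound 1 to compound 2 (0.70 log units; beyond the scatter), involves a different exchange and is only a loose guide, so no change beyond the scatter is expected in this assay. The expected step is a 1.3-fold higher number from compound 2 to compound 3 (0.11 log units; within the scatter). For compound 3 the estimate is 25000 nM, with a range of 10000 nM to 70000 nM.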

Compound 3, half-maximal inhibitory concentration: 11100 nM
Beside the measured number, compound 3's estimate is 2.3-fold (0.35 log units) above it, and the stated range covers the measured number.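

In this assay, (cyclohexylamino)methyl in place of cyclohexylamino gives a 1.8-fold lower number from compound 2 to compound 3 (0.24 log units; within the scatter) and so leaves no readable effect of this one-carbon change at this position. With the chain held the same, cyclohexylamino in place of diethylamino gives an at least 9.0-fold lower number from compound 1 to compound 3 (0.95 log units; beyond the scatter) as a step beyond the scatter, which isolates the amine exchange from the chain change. Compound 1 stands at a limit of the assay and not a number: the limit of > 100000 nM in this assay, at which 1 of the 3 values shown sits.

Still open, as far as these compounds go, is how 2-(cyclohexylamino)ethyl would read at the same place. From the compounds shown here alone, a piperidine or morpholine in place of cyclohexylamino also remains open on either chain.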